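Working notes: methoxy to trifluoromethoxy on compound 2

The compounds below may be only part of what the source reports. "The series", "measured", "known", "first", "only" and "open" are said of these compounds alone.

Values so far in an ADME assay on HepG2 cells (Homo sapiens) for cytotoxicity, with a stated time of 72 h; a higher number here means that more compound is needed for the effect, a lower number that less compound is needed
- Compound 1 (`COC(=O)c1cccc(NC(=O)Nc2cc(C)nc3ccccc23)c1`) gives 23000 nM
- Compound 2 (`COc1cccc(NC(=O)Nc2cc(C)nc3ccccc23)c1`) gives > 25000 nM as a limit

Compound 2 has no exact number in this assay and stands only at a limit (> 25000 nM). For the measured compounds named here, this is the one case of the limit of > 25000 nM in this assay, at which 1 of the 2 values shown sits, so far.

Compound 3 (`Cc1cc(NC(=O)Nc2cccc(OC(F)(F)F)c2)c2ccccc2n1`) carries trifluoromethyl in place of methyl on an oxygen on an aromatic ring. The same difference reads methoxy to trifluoromethoxy.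

Going by the values given here, the only measured step is an at least 1.0-fold higher number from compound 1 to compound 2 (0.03 log units; that floor lies within the scatter) and it gives an open-ended floor, not a size. It also concerns a change on an aromatic carbon, so it bears on the new change only loosely. Among the compounds with values here, no measured step covers the change from methoxy to trifluoromethoxy. No step beyond the scatter is therefore expected in this assay, in either direction.

The expected step is an at least 1.1-fold lower number from compound 2 to compound 3 (0.05 log units; that floor lies within the scatter) (an estimate). Compound 3 is expected at 22000 nM (estimated range 11000 nM to 32000 nM).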

Compound 3, half-maximal effective concentration: 13000 nM
The estimate for compound 3 lay 1.7-fold (0.23 log units) above the measured number; the range from low to high includes it.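

On an oxygen on an aromatic ring, trifluoromethyl in place of methyl now has a reading in this assay: an at least 1.9-fold lower number from compound 2 to compound 3 (0.28 log units; that floor lies within the scatter), which is an open-ended floor and not a size, so the real step could be larger than this figure. Compound 2 carries only a limit, and this floor rests on it: the limit of > 25000 nM in this assay, at which 1 of the 3 values shown sits.

Against the methoxycarbonyl group of compound 1, the trifluoromethoxy group gives an exact comparison, a 1.8-fold lower number from compound 1 to compound 3 (0.25 log units; within the scatter), so this pair of exact numbers shows no separation in this assay.

The compounds shown cannot settle whether the change from methoxy to trifluoromethoxy moves the number beyond the scatter, as compound 2 has no exact value to measure the step against. Also open, going by these compounds, is how an amine, a carboxylic acid or a longer alkoxy chain in this place on the aromatic ring would read in this assay, and whether the trifluoromethoxy reading holds on any core other than the one shared here.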